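Notes on a difluorophenyl swap in compound 2

This account rests on a few compounds, and the source may have more. Where it says the series, first, only, none or still open, it means among the compounds named here.

In an ADME assay on microsomes from liver (Homo sapiens) for metabolic stability (on this read-out higher numbers stand for fast clearance and lower numbers for slow clearance), compound 2 `O=C(CCCN1CCCCCC1)Nc1cnc(-c2ccc(F)cc2F)s1` gives 42 mL.min-1.g-1. Compound 1 `O=C(CCCN1CCCCCC1)Nc1nnc(-c2ccc(F)cc2)s1` gives 39 mL.min-1.g-1, which is within the scatter of compound 2. Compound 3 `O=C(CCCN1CCCCC1)Nc1cnc(-c2ccc(F)cc2)s1` gives 15 mL.min-1.g-1, lower than compound 2 by more than the scatter. Among the compounds with values here, compound 2 therefore sits with compound 1 at the upper end of the numbers so far.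

Compound 4 `O=C(CCCN1CCCCCC1)Nc1cnc(-c2ccc(F)c(F)c2)s1` carries 3,4-difluorophenyl in place of 2,4-difluorophenyl on an aromatic carbon. The two compounds have the same atoms, joined differently. Within the data shown here, no measured pair differs in one place only, so the data give no direct reading of this change. Among the measured compounds shown here, compound 1 and compound 2 differ in more than one place, yet their values stay within the scatter of each other, and this is the only guide available. The expected step of a 1.1-fold lower number from compound 2 to compound 4 (0.04 log units; within the scatter) stays within the scatter, with no firm direction. In this assay, the estimated value for compound 4 is 38 mL.min-1.g-1, with an expected range of 18 mL.min-1.g-1 to 75 mL.min-1.g-1.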

Compound 4, intrinsic clearance in microsomes in the Homo sapiens assay: 42 mL.min-1.g-1
The estimate for compound 4 lay 1.1-fold (0.04 log units) below the measured number, and the stated range covers the measured number.
By their numbers in the Homo sapiens assay, from the lowest: compound 3; then compounds 1, 2 and 4 (each within the scatter of the next).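

In the Homo sapiens assay, compound 2 gives 42 mL.min-1.g-1 and compound 4 gives 42 mL.min-1.g-1. Within the data shown here, in the Homo sapiens assay, 3,4-difluorophenyl in place of 2,4-difluorophenyl gives no change at the digits printed from compound 2 to compound 4 (within the scatter); this is the first step that differs in one place only, and it shows that this read-out does not separate the two fluorine arrangements on this aromatic carbon. In a physicochemical assay for lipophilicity, read by LC-MS, measured as octanol-water partition, with a stated time of 18 h, at pH 7.4 (on this read-out lower numbers stand for lower lipophilicity and higher numbers for higher lipophilicity), compound 2 gives 2.11 and compound 4 gives 2.3. In the physicochemical assay, the same change gives a number 0.19 log units higher from compound 2 to compound 4 (within the scatter), so the two arrangements are not separated on that read-out either. No available evidence bears on why the two compounds read alike.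

Still open, as far as these compounds go, is whether a different group on the phenyl ring, such as methoxy or a nitrile, would give a number beyond the scatter of these two compounds. Also open, from the compounds shown here alone, is how an unsubstituted phenyl at the same place would read in either assay.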